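Cyano to nitro on the benzyl ring of compound 3

The compounds below may be only part of what the source reports. "The series", "measured", "known", "first", "only" and "open" are said of these compounds alone.

Compound 1 `COC(=O)c1ccc(NCc2cncn2Cc2cccc(C)c2)cc1-c1ccccc1`: > 10000 nM
Compound 2 `COC(=O)c1ccc(NCc2cncn2Cc2ccccc2OC)cc1-c1ccccc1`: "not determined" (no result reported)
Compound 3 `COC(=O)c1ccc(NCc2cncn2Cc2ccccc2C#N)cc1-c1ccccc1`: 25000 nM

In a toxicity assay on NIH3T3 cells (Mus musculus) for cytotoxicity, read by resazurin assay (a lower number here means that less compound is needed, a higher number that more compound is needed for the effect), compound 1 shows only a limit, > 10000 nM. For compound 2 no result is reported. Among the compounds with values here, compound 3 gives the single number, 25000 nM. The step that the limit leaves unreadable from compound 1 to compound 3 cannot be sized because the limit of > 10000 nM in this assay, at which 1 of the 3 values shown sits, hides the starting point. Compound 4 `COC(=O)c1ccc(NCc2cncn2Cc2ccccc2[N+](=O)[O-])cc1-c1ccccc1` differs from compound 3 by nitro in place of cyano on an aromatic carbon. Within the data shown here, no measured step speaks to this change, so no shift beyond the usual scatter is expected. Compound 4 is therefore estimated at 25000 nM, within 8000 nM to 70000 nM. The expected step is no change at the digits printed from compound 3 to compound 4 (within the scatter).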

Compound 4, half-maximal effective concentration: 10000 nM
For compound 4 the middle estimate is 2.5-fold (0.40 log units) above the measured one, and the stated range covers the measured number.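

In this assay, within the data shown here, nitro in place of cyano on an aromatic carbon gives a 2.5-fold lower number from compound 3 to compound 4 (0.40 log units; beyond the scatter), the first step whose size can be read. It shows that the number responds to the group on this aromatic carbon, although the step is modest. Steps that start from a limit cannot be read, and so all that can be stated here is a number no higher from compound 1 to compound 4 (the limit leaves the size open): the limit of > 10000 nM in this assay, at which 1 of the 4 values shown sits.

The compounds shown leave open how an amine or a carboxylic acid on this aromatic carbon would read in this assay. They also leave open whether a group with a longer chain here would move the number further.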